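This account rests on a few compounds, and the source may have more. Where it says the series, first, only, none or still open, it means among the compounds named here.

Measured so far in a functional assay on A549 cells (Homo sapiens) for antiproliferative activity, read by MTT assay, with a stated time of 72 h; on this read-out lower numbers stand for stronger inhibition and higher numbers for weaker inhibition:

- compound 1 `Nc1nc(N)c2cc(CSC(=S)N3CCN(c4ccccc4)CC3)ccc2n1` gives 2970 nM
- compound 2 `Nc1nc(N)c2cc(CSC(=S)N3CCN(c4ccc(O)cc4)CC3)ccc2n1` gives 4210 nM
- compound 3 `Nc1nc(N)c2cc(CSC(=S)N3CCN(c4ccc(Cl)cc4)CC3)ccc2n1` gives 5210 nM

Compound 3 with 5210 nM stands within the scatter of both compound 1 and compound 2, so the three cannot be ranked against one another.

The next compound is compound 4 `Nc1nc(N)c2cc(CSC(=S)N3CCN(c4ccccc4Cl)CC3)ccc2n1`, which keeps the atoms of compound 3 but joins them differently: 2-chlorophenyl in place of 4-chlorophenyl on an amine nitrogen in a ring. Among the measured compounds shown here, no measured compound carries 2-chlorophenyl, so no measured step shows this exact change. The closest evidence comes from changes on the same aromatic ring. These are a 1.8-fold higher number from compound 1 to compound 3 (0.24 log units; within the scatter), a 1.4-fold higher number from compound 1 to compound 2 (0.15 log units; within the scatter) and a 1.2-fold higher number from compound 2 to compound 3 (0.09 log units; within the scatter). All three stay within the scatter, so hydrogen, hydroxy and chloro at the 4-position of the phenyl group have not separated in this assay. Three compounds are a narrow basis, and they say nothing direct about the 2-position. On that basis, no step beyond the scatter is expected in either direction.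

The expected change is a 1.2-fold lower number from compound 3 to compound 4 (0.06 log units; within the scatter) and remains an estimate. For compound 4 the estimated value is 4500 nM and the expected range runs from 2000 nM to 9500 nM.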

Compound 4, half-maximal inhibitory concentration: 3610 nM
Beside the measured number, compound 4's estimate is 1.2-fold (0.10 log units) above it; the measured number falls inside the stated range.
By their numbers in this assay, from the lowest: compounds 1, 4, 2 and 3 (each within the scatter of the next).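

Moving the chlorine around the phenyl group is a change that the earlier compounds, all substituted at the 4-position or unsubstituted, could not address, and in this assay the exchange of 4-chlorophenyl for 2-chlorophenyl on the ring nitrogen comes to a 1.4-fold lower number from compound 3 to compound 4 (0.16 log units; within the scatter), so the two placements of chloro do not separate on this read-out. The new compound is equally unresolved from the other two, with a 1.2-fold lower number from compound 2 to compound 4 (0.07 log units; within the scatter) and a 1.2-fold higher number from compound 1 to compound 4 (0.08 log units; within the scatter), which means that phenyl, 4-hydroxyphenyl, 4-chlorophenyl and 2-chlorophenyl now form a single set of values that cannot be ranked, and the scatter-level behaviour seen at the 4-position extends to this second position. No supporting measurement bears on this result or offers an explanation for it.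

As far as these compounds go, whether any group on this phenyl ring can move the number beyond the scatter remains open, since only hydroxy and chloro appear on it, and a methoxy group, an amine or a carboxylic acid would test this further. All four compounds also share the same core and the same link to the piperazine-type ring, so the compounds shown say nothing about what a longer chain at that link would do.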